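Swapping the urea substituent on a nitrooxy-bearing core

This account rests on a few compounds, and the source may have more. Where it says the series, first, only, none or still open, it means among the compounds named here.

Three compounds share one core, a quinazolinone-like ring bearing a urea on its nitrogen, and were tested in a functional assay on the whole organism (strain Sprague-Dawley) for inhibition, with Rattus norvegicus as the target, read by paw edema, with stated times of 30 min and 3 h, at a dose of 80 mg/kg by the oral route; on this read-out lower numbers stand for less inhibition and higher numbers for more inhibition at the one dose given (going by the name of the read-out). Compound 1, `Cc1nc2ccccc2c(=O)n1NC(=O)NC1CCCCC1`, carries a cyclohexyl group on the urea and gives 54.8%. Compound 2, `Cc1nc2ccccc2c(=O)n1NC(=O)NC(C)(C)C`, carries a tert-butyl group instead, and compound 2 gives 51%; the step of a number 3.8 percentage points lower from compound 1 to compound 2 (within the scatter) is within the scatter. Compound 3, `CC(C)(C)NC(=O)Nn1c(CO[N+](=O)[O-])nc2ccccc2c1=O`, adds a nitrooxy group to the methyl of compound 2, and compound 3 gives 43.7%; the step of a number 7.3 percentage points lower from compound 2 to compound 3 (within the scatter) is also within the scatter. Compound 3 thus stands lowest of the three numbers, with the gap to compound 2 inside the usual scatter and the gap to compound 1 beyond it.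

Compound 4, `O=C(NC1CCCCC1)Nn1c(CO[N+](=O)[O-])nc2ccccc2c1=O`, differs from compound 3 in one place: cyclohexyl in place of tert-butyl on an amide-type nitrogen. For the measured compounds named here, the only measured step bearing on this change is the one from compound 1 to compound 2, which is the same exchange in the opposite direction and was within the scatter. The expectation for the step into compound 4 is therefore a small rise at most, a number 3.8 percentage points higher from compound 3 to compound 4 (within the scatter), not beyond the scatter. Compound 4 is estimated to give 47.5%, expected to lie between 38% and 57%.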

Compound 4, a percentage reported as inhibition, in the whole organism at one dose (the size of the read-out at that dose, not a potency): 49.9%
Beside the measured number, compound 4's estimate is 2.4 percentage points below it; the measured number falls inside the stated range.
By their numbers in this assay, from the lowest: compounds 3, 4, 2 and 1 (each within the scatter of the next, the first and the last beyond it).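

In this assay, the exchange of tert-butyl for cyclohexyl on the amide-type nitrogen can now be read on the core that carries the nitrooxy group, as a number 6.2 percentage points higher from compound 3 to compound 4 (within the scatter), and it agrees with the reading on the core without that group: the same change on two cores in this assay, a number 3.8 percentage points lower (within the scatter) from compound 1 to compound 2 and a number 6.2 percentage points lower (within the scatter) from compound 4 to compound 3, 2.4 percentage points apart, within the scatter of two such steps

The nitrooxy change can likewise now be read a second time, with cyclohexyl instead of tert-butyl on the urea, as a number 4.9 percentage points lower from compound 1 to compound 4 (within the scatter), and again the two readings agree: the same change on two cores in this assay, a number 7.3 percentage points lower (within the scatter) from compound 2 to compound 3 and a number 4.9 percentage points lower (within the scatter) from compound 1 to compound 4, 2.4 percentage points apart, within the scatter of two such steps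

Taken together, neither change moves the number beyond the scatter on either partner, and the size of each step shows no dependence on the other change across these four compounds.

The compounds shown cover only two saturated carbon groups on the amide-type nitrogen, so it stays open whether a phenyl ring or a longer straight chain there would shift the number beyond the scatter. From the compounds shown here alone, it also stays open whether a hydroxyl group in place of the nitrooxy group would give a step of similar size.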